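From benzyl to phenyl: what happens to clearance?

The compounds below may be only part of what the source reports. "The series", "measured", "known", "first", "only" and "open" are said of these compounds alone.

In an ADME assay on liver for metabolic stability, with Liver microsome (Homo sapiens) as the target, read by LC-MS, using microsomes (a higher number here means faster removal of the compound, a lower number slower removal), compound 1 `CCCC[C@@H](O)C(=O)N1C[C@H]2C[C@H]2[C@H]1C(=O)NCc1cc(Cl)ccc1-n1cnnn1` gives 32 mL.min-1.g-1 and compound 2 `O=C(NCc1cc(Cl)ccc1-n1cnnn1)[C@@H]1[C@@H]2C[C@@H]2CN1C(=O)[C@H](O)Cc1ccccc1` gives 74 mL.min-1.g-1, the higher of the two numbers. Compound 3 `O=C(NCc1cc(Cl)ccc1-n1cnnn1)[C@@H]1[C@@H]2C[C@@H]2CN1C(=O)[C@H](O)c1ccccc1` differs from compound 2 by one change: phenyl in place of benzyl on a saturated chain carbon bound to a carbonyl carbon and an oxygen on a saturated carbon. In words, phenyl replaces benzyl on a saturated chain carbon bound to a carbonyl carbon and an oxygen on a saturated carbon. Within the data shown here, only one measured step bears on this, a 2.3-fold higher number from compound 1 to compound 2 (0.36 log units; beyond the scatter), and it is a different change, so it offers only a rough guide to size. The expected change is small, a 1.3-fold lower number from compound 2 to compound 3 (0.13 log units; within the scatter). For compound 3 the estimated value is 55 mL.min-1.g-1, with an expected range from 25 mL.min-1.g-1 to 110 mL.min-1.g-1.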

Compound 3, intrinsic clearance in microsomes: < 15 mL.min-1.g-1
Compound 3: only a limit was reported; the forecaster's own chance of this, stated with the estimate: 3%; middle value at least 3.6-fold (0.56 log units) away from the limit.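

In this assay, the group on this saturated chain carbon strongly affects the result: phenyl in place of benzyl gives an at least 4.9-fold lower number from compound 2 to compound 3 (0.69 log units; beyond the scatter). An aromatic ring here does not by itself raise the number, since phenyl in place of butyl gives an at least 2.1-fold lower number from compound 1 to compound 3 (0.32 log units; beyond the scatter). The reading for compound 3 is a limit of the assay, not a number: the limit of < 15 mL.min-1.g-1 in this assay, at which 1 of the 3 values shown sits.

From the compounds shown here alone, how far the number falls with phenyl therefore stays open. So does whether a pyridyl ring or a phenethyl group at this position would also keep it low.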